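This account rests on a few compounds, and the source may have more. Where it says the series, first, only, none or still open, it means among the compounds named here.

Measured in an ADME assay on J774 cells (Mus musculus) for cytotoxicity, read by resazurin assay, with a stated time of 72 h; a higher number here means that more compound is tolerated, a lower number that less compound is tolerated:
- Compound 1 `C/C(=N\Nc1nc(C)cs1)c1ccc(Cl)c(Cl)c1`: 33700 nM
- Compound 2 `C/C(=N\Nc1nc(-c2ccc(C)cc2)cs1)c1ccc(Cl)c(Cl)c1`: > 50000 nM (a limit)
- Compound 3 `C/C(=N\Nc1nc(-c2ccc(Cl)c(Cl)c2)cs1)c1ccc(Cl)c(Cl)c1`: > 50000 nM (a limit)

Compound 2 has no exact number, and its reading of > 50000 nM is a limit. It sits at the limit of > 50000 nM in this assay, at which 2 of the 3 values shown sit. Compound 4 `C/C(=N\Nc1nc(-c2ccc(-c3ccccc3)cc2)cs1)c1ccc(Cl)c(Cl)c1` differs from compound 2 by phenyl in place of methyl on an aromatic carbon, with phenyl in place of methyl on an aromatic carbon, para to a large group. The nearest evidence is a step that the two limits leave unreadable from compound 2 to compound 3. Two further steps give only floors within the scatter: an at least 1.4-fold higher number from compound 1 to compound 2 (0.17 log units; that floor lies within the scatter) and an at least 1.4-fold higher number from compound 1 to compound 3 (0.17 log units; that floor lies within the scatter). No step beyond the scatter is therefore expected in this assay, and another limit reading is quite likely. The expected change is a number no higher from compound 2 to compound 4 (the limit leaves the size open). For compound 4 the estimated value is 50000 nM, with an expected range of 22000 nM to 80000 nM.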

Compound 4, half-maximal cytotoxic concentration: > 50000 nM
Compound 4 ended at the assay's limit; the forecaster's own chance of this, stated with the estimate: 65%; the middle value sits exactly at the limit.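

Among the compounds shown here, compound 4 gives > 50000 nM, a limit, and compound 2 also stands at a limit, so no step between compound 2 and compound 4 can be read in this assay. The compounds shown leave open whether phenyl in place of methyl changes the tolerated concentration at all.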